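Flavone acetamides: methoxy for fluoro on the anilide ring

The source may hold more compounds than are shown below. What is called first, only, known or untested is meant among the compounds shown, and "the series" means these compounds.

In a functional assay on NCI-H661 cells (Homo sapiens) for antiproliferative activity, read by MTT assay, with a stated time of 72 h (a higher number here means a weaker inhibitor of growth, a lower number a stronger inhibitor of growth), compound 1 `O=C(COc1c(-c2ccccc2)oc2ccccc2c1=O)Nc1ccc(F)cc1` gives only a limit, > 10000 nM (the limit of > 10000 nM in this assay, at which 1 of the 3 values shown sits). Compound 2 `COc1ccc(NC(=O)COc2c(-c3ccccc3)oc3ccccc3c2=O)cc1` gives 6740 nM. The change methoxy in place of fluoro on an aromatic carbon thus made an at least 1.4-fold lower number from compound 1 to compound 2 (0.17 log units; that floor lies within the scatter). Compound 3 `O=C(COc1ccc2oc(-c3ccccc3)cc(=O)c2c1)Nc1ccc(F)cc1` carries the same side chain on a differently joined core; the difference between the two cores is not broken down here. In this assay compound 3 gives 1470 nM, the lowest number among the measured pair with a number. Compound 4 `COc1ccc(NC(=O)COc2ccc3oc(-c4ccccc4)cc(=O)c3c2)cc1` is not yet measured; it repeats the same change on the core of compound 3, (methoxy in place of fluoro on an aromatic carbon). The step from compound 3 to compound 4 is expected to be a 1.5-fold lower number from compound 3 to compound 4 (0.17 log units; within the scatter), resting on the step of an at least 1.4-fold lower number from compound 1 to compound 2 (0.17 log units; that floor lies within the scatter). In this assay compound 4 is estimated at 1000 nM, between 400 nM and 3000 nM.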

Compound 4, concentration for 50% growth inhibition: 840 nM
For compound 4 the middle estimate is 1.2-fold (0.08 log units) above the measured one; measured number inside the range.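

On the core of compound 3, methoxy in place of fluoro gives a 1.8-fold lower number from compound 3 to compound 4 (0.24 log units; within the scatter) in this assay, so this step alone shows no change that stands clear of the scatter. Set beside the step on the core of compound 1, it does not show that the change carries over with the same size, nor that its size depends on the core: the same change on two cores in this assay, an at least 1.4-fold lower number (0.17 log units; that floor lies within the scatter) from compound 1 to compound 2 and a 1.8-fold lower number (0.24 log units; within the scatter) from compound 3 to compound 4; the limit leaves it open whether they differ. Compound 1 gives only a limit, so its step has a floor and no size: the limit of > 10000 nM in this assay, at which 1 of the 4 values shown sits.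

Open, as far as these compounds go, is whether an amine or a carboxylic acid in place of fluoro would give a step beyond the scatter on either core. Also open, from the compounds shown here alone, is how a longer chain between the core and the amide would read in this assay.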